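A few compounds are considered here, and "the series" means these few. Any claim that something is new, unique, unknown or untested is made for them only; others in the source may bear on it.

Measured in a functional assay on HepG2 cells (Homo sapiens) for antiproliferative activity, read by MTT assay, with a stated time of 72 h; on this read-out higher numbers stand for weaker inhibition and lower numbers for stronger inhibition:

- compound 1 `COc1cc(CCc2ccc(Cl)c(Cl)c2)cc(OC)c1O`: 16100 nM
- compound 2 `COc1ccc(CCc2ccccn2)cc1OC`: 13800 nM
- compound 3 `COc1cc(CCc2ccccc2F)cc(OC)c1O`: 1030 nM

Compound 1 has the highest of these three numbers, which marks the weakest inhibition on the scale, but it cannot be separated from compound 2, since the two values lie within the usual scatter of repeated measurements. Set against compound 1, compound 3 stands well apart, with a clearly lower number of 1030 nM.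

The next compound to be tested is compound 4 `COc1cc(CCc2ccc(Cl)cc2)cc(OC)c1O`, which is compound 1 with one change: hydrogen in place of chloro on an aromatic carbon. In words, hydrogen takes the place of chloro on an aromatic carbon, at a place ortho to a chloro group and meta to a large group.

Within the data shown here, no measured pair in this small set differs by a single change, so there is no direct precedent for the size of this step. Compound 3, at 1030 nM, does show that a compound sharing the core of compound 1 can reach a much lower number in this assay, though it differs from compound 1 in more than one place. A modest move towards a lower number is therefore expected, possibly no larger than the scatter. The estimated change is a 1.8-fold lower number from compound 1 to compound 4 (0.25 log units; within the scatter). For compound 4 the expected value is 9000 nM, with an estimated range of 2500 nM to 30000 nM.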

Compound 4, half-maximal inhibitory concentration: 8780 nM
Compound 4: the middle estimate sits 1.0-fold (0.01 log units) above what was measured; low and high end bracket the measured number.
By their numbers in this assay, from the lowest: compound 3; then compounds 4, 2 and 1 (each within the scatter of the next).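

Among these compounds, compound 4 gives the first pair in this set that differs in only one place. In this assay, putting hydrogen in place of chloro on an aromatic carbon, at a place ortho to a chloro group and meta to a large group, gives a 1.8-fold lower number from compound 1 to compound 4 (0.26 log units; within the scatter). This single pair therefore gives no sign that this chloro group matters in this assay, although a small real effect could be hidden within the ordinary spread of repeated measurements, and nothing available here offers an explanation for the result.

The compounds shown do not reveal what the remaining chloro group contributes, since no pair here isolates a change at that group. They also leave open whether a different group at the position studied here, such as a methyl group, an amine or a carboxylic acid, would shift the number beyond the scatter, or whether this position tolerates a wide range of groups.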